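Cytotoxicity Step from Compound 2 to Compound 3

The compounds below may be only part of what the source reports. "The series", "measured", "known", "first", "only" and "open" are said of these compounds alone.

Compound 1: `O=C1C(c2ccc(O)cc2)=C(c2ccc(F)cc2)C(=O)N1CCC(O)(c1ccccc1)c1ccccc1` — > 100000 nM
Compound 2: `CCN(CC)CCCOc1ccc(C2=C(c3ccc(F)cc3)C(=O)N(CCC(O)(c3ccccc3)c3ccccc3)C2=O)cc1` — 32700 nM

In an ADME assay on HEK293 cells (Homo sapiens) for cytotoxicity, read by MTT assay, with a stated time of 48 h (a higher number here means that more compound is tolerated, a lower number that less compound is tolerated), compound 1 gives > 100000 nM, which is a limit of the assay rather than a number. Compound 2 gives 32700 nM in this assay. The step between them is an at least 3.0-fold lower number from compound 1 to compound 2 (0.48 log units; beyond the scatter). Within the data shown here, compound 2 therefore holds the only number in this assay, the other value being the limit described in the limit of > 100000 nM in this assay, at which 1 of the 2 values shown sits.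

Compound 3 `CCN(CC)CCCCOc1ccc(C2=C(c3ccc(F)cc3)C(=O)N(CCC(O)(c3ccccc3)c3ccccc3)C2=O)cc1` differs from compound 2 by (diethylamino)methyl in place of diethylamino on a saturated chain carbon, three bonds along the chain from an oxygen on an aromatic ring. Among the measured compounds shown here, the only measured step, from compound 1 to compound 2, concerns the attachment of the whole amine-bearing chain to the aromatic oxygen; it does not speak to a change in the length of that chain. For the measured compounds named here, with no measured step of this kind, the expected change in this assay for compound 3 is none beyond the scatter, a 1.1-fold lower number from compound 2 to compound 3 (0.04 log units; within the scatter). Compound 3 is thus estimated at 30000 nM in this assay, within a range from 12000 nM to 80000 nM.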

Compound 3, concentration lethal to 50% of the cells in the HEK293 assay: 47300 nM
Compound 3: the middle estimate sits 1.6-fold (0.20 log units) below what was measured; low and high end bracket the measured number.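

Among these compounds, in the HEK293 assay, the one change at this position, (diethylamino)methyl in place of diethylamino on a saturated chain carbon, three bonds along the chain from an oxygen on an aromatic ring, gives a 1.4-fold higher number from compound 2 to compound 3 (0.16 log units; within the scatter), so 3-(diethylamino)propyl and 4-(diethylamino)butyl on that oxygen cannot be told apart in this assay. Set against the hydrogen on the same oxygen, the 4-(diethylamino)butyl chain still gives an at least 2.1-fold lower number from compound 1 to compound 3 (0.32 log units; beyond the scatter), so the separation from compound 1 that the shorter chain showed also appears with the longer one, although this step rests on a limit of the assay: the limit of > 100000 nM in the HEK293 assay, at which 1 of the 3 values shown sits. In a physicochemical assay for lipophilicity, read by HPLC, measured as octanol-water partition, with a stated time of 4 h (a lower number here means a more polar compound, a higher number a more lipophilic compound), compound 2 gives > 5, which is a limit of the assay and not a number. In the physicochemical assay compound 3 gives > 5, which is also a limit of the assay and not a number. In the physicochemical assay the step from compound 2 to compound 3 cannot be read, since both compounds give a limit and not a number: the limit of > 5 in the physicochemical assay, at which 2 of the 2 values shown sit.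

From the compounds shown here alone, what a chain longer than 4-(diethylamino)butyl, or one shorter than 3-(diethylamino)propyl, would give in the HEK293 assay stays open. So does the outcome of replacing the diethylamino end of the chain with another amine, such as dimethylamino or morpholine, or with a carboxylic acid.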